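A Ring-Bearing Ester Gives Way to a Shorter Chain

The source may report more compounds than this note shows. Statements on the series, on what has been measured and on what is new or still open speak of the compounds shown alone.

Measured so far in a physicochemical assay for solubility, read by nephelometry, measured as kinetic solubility; on this read-out higher numbers stand for higher solubility and lower numbers for lower solubility
compound 1 `CCC/N=C1\S/C(=C\c2ccc(C(=O)NCC(=O)N(C)C)cc2)C(=O)N1c1ccccc1O` gives 219000 nM
compound 2 `CCC/N=C1\S/C(=C\c2ccc(C(=O)OCCCO)cc2)C(=O)N1c1ccccc1O` gives 183000 nM
compound 3 `CCC/N=C1\S/C(=C\c2ccc(C(=O)OCc3oc(=O)oc3C)cc2)C(=O)N1c1ccccc1O` gives 79000 nM

Compound 3 has the lowest of these three numbers. Compound 4 `CCC/N=C1\S/C(=C\c2ccc(CCC(=O)OC)cc2)C(=O)N1c1ccccc1O` is still unmeasured and differs from it at one place: a group of 6 heavy atoms (4 carbon, 2 oxygen; no ring) in place of a group of 11 heavy atoms (6 carbon, 5 oxygen; one five-membered aromatic ring with 2 hetero atoms), on an aromatic carbon. Going by the values given here, no measured step makes this exact change, but three altered the same substituent. They show a 1.2-fold lower number from compound 1 to compound 2 (0.08 log units; within the scatter), a 2.8-fold lower number from compound 1 to compound 3 (0.44 log units; beyond the scatter) and a 2.3-fold lower number from compound 2 to compound 3 (0.36 log units; beyond the scatter). The last two steps brought in the five-membered aromatic ring that compound 4 lacks, so a small move back up is possible. No step beyond the scatter is expected, and the expected step is a 1.3-fold higher number from compound 3 to compound 4 (0.10 log units; within the scatter). For compound 4 the estimated value is 100000 nM, with an expected range from 35000 nM to 220000 nM.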

Compound 4, solubility: 79000 nM
Compound 4: the middle estimate sits 1.3-fold (0.10 log units) above what was measured; low and high end bracket the measured number.
By their numbers in this assay, from the lowest: compounds 3 and 4 (each within the scatter of the next); then compounds 2 and 1 (each within the scatter of the next).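

On this aromatic carbon, 2-(methoxycarbonyl)ethyl replaces the larger ring-bearing group in this assay with no change at the digits printed from compound 3 to compound 4 (within the scatter), so removing the five-membered aromatic ring leaves the number in place. The ring-free compound 4 still lies apart from the ring-free earlier compounds, with a 2.3-fold lower number from compound 2 to compound 4 (0.36 log units; beyond the scatter) and a 2.8-fold lower number from compound 1 to compound 4 (0.44 log units; beyond the scatter), so the ring alone does not separate compound 3 from them. Nothing measured here explains these numbers. The compounds shown leave open whether a carboxylic acid or an amine on this aromatic carbon would fall nearer compound 1 or compound 4.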